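A Branched Carboxy Chain on the Amide Nitrogen

The source may hold more compounds than are shown below. What is called first, only, known or untested is meant among the compounds shown, and "the series" means these compounds.

In a functional assay on PC-3 cells (Homo sapiens) for antiproliferative activity, read by MTT assay, with a stated time of 72 h (on this read-out higher numbers stand for weaker inhibition and lower numbers for stronger inhibition), compound 1 (`CCn1cc(C(CC)(CC)c2ccc(C#CC(O)(CC)CC)c(C)c2)cc1C(=O)OCCO`) gives 11400 nM. Compound 2 (`CCn1cc(C(CC)(CC)c2ccc(C#CC(O)(CC)CC)c(C)c2)cc1C(=O)NCCC(=O)O`) sits at the limit of > 50000 nM in this assay, at which 1 of the 2 values shown sits: its > 50000 nM is a limit and not a number.

Compound 3 (`CCn1cc(C(CC)(CC)c2ccc(C#CC(O)(CC)CC)c(C)c2)cc1C(=O)N[C@H](C(=O)O)C(C)C`) differs from compound 2 in one place: 1-carboxy-2-methylpropyl in place of 2-carboxyethyl on an amide-type nitrogen. In words, 1-carboxy-2-methylpropyl stands in place of 2-carboxyethyl on an amide-type nitrogen.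

Among the measured compounds shown here, only one measured step bears on this change, and it does so indirectly. That step, an at least 4.3-fold higher number from compound 1 to compound 2 (0.64 log units; beyond the scatter), lies beyond the scatter and is at least modest. It introduced the 2-carboxyethyl group, and compound 3 keeps a carboxy-bearing chain on the same nitrogen. For the measured compounds named here, no measured step alters that chain itself, so the size of the new step cannot be read directly from the data.

In this assay, no change beyond the scatter is therefore expected, and a second limit reading is quite possible. The expected step is a number no higher from compound 2 to compound 3 (the limit leaves the size open). For compound 3 the estimate is 50000 nM, with an expected range from 20000 nM to 120000 nM.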

Compound 3, half-maximal inhibitory concentration: 3750 nM
For compound 3 the middle estimate is 13-fold (1.12 log units) above the measured one; measured number outside the range, below it.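

In this assay, a carboxy-bearing chain on the amide-type nitrogen proves compatible with antiproliferative activity: 1-carboxy-2-methylpropyl in place of 2-carboxyethyl gives an at least 13-fold lower number from compound 2 to compound 3 (1.12 log units; beyond the scatter). The earlier step had shown only a loss with such a chain, whereas a 3.0-fold lower number from compound 1 to compound 3 (0.48 log units; beyond the scatter) shows that one carboxy-bearing chain on this nitrogen can outdo the 2-hydroxyethoxy group, so the outcome here is not set by the presence of a carboxy group alone. The exact size of the gain stays open, since compound 2 gives a limit and not a number: the limit of > 50000 nM in this assay, at which 1 of the 3 values shown sits.

The entering group differs from the leaving one both in its heavy-atom count and in its defined stereocentre, and the compounds shown do not tell these differences apart. As far as these compounds go, it also remains open how the opposite stereoisomer, a smaller 1-carboxyethyl chain, a larger 1-carboxy-2-phenylethyl chain, or a 1-(hydroxymethyl)-2-methylpropyl chain, with a hydroxyl in place of the carboxylic acid, would read on this nitrogen.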